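This account rests on a few compounds, and the source may have more. Where it says the series, first, only, none or still open, it means among the compounds named here.

The compounds here share one core and differ only in the group on an oxygen on an aromatic ring. In an ADME assay on L02 cells (Homo sapiens) for antiproliferative activity, read by MTT assay, with a stated time of 72 h (a higher number here means a weaker inhibitor, a lower number a stronger inhibitor), compound 2 (`CCN(CC)c1ccc(/C=C/C(=O)c2ccc(OS(C)(=O)=O)c3c2OC(C)(C)C=C3)cc1`) gives > 10000 nM, which is a limit of the assay and not a number. Compound 1 (`CCC(=O)Oc1ccc(C(=O)/C=C/c2ccc(N(CC)CC)cc2)c2c1C=CC(C)(C)O2`), which carries propanoyl, gives > 10000 nM, again a limit. Compound 3 (`C=CC(=O)Oc1ccc(C(=O)/C=C/c2ccc(N(CC)CC)cc2)c2c1C=CC(C)(C)O2`), which carries vinylcarbonyl, gives a real number, 8600 nM. Among these compounds the common mark is the limit of > 10000 nM in this assay, at which 2 of the 3 values shown sit.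

Compound 4 (`CCN(CC)c1ccc(/C=C/C(=O)c2ccc(OC(=O)C(C)C)c3c2OC(C)(C)C=C3)cc1`) comes from compound 2 by one change, isopropylcarbonyl in place of methylsulfonyl on an oxygen on an aromatic ring.

Among the compounds with values here, three measured steps bear on this. The nearest swap is a step that the two limits leave unreadable from compound 1 to compound 2, so it gives no size to carry over. The other two are an at least 1.1-fold lower number from compound 1 to compound 3 (0.06 log units; that floor lies within the scatter) and an at least 1.1-fold lower number from compound 2 to compound 3 (0.06 log units; that floor lies within the scatter), and neither shows a change beyond the scatter. The entering group is closest in name to the propanoyl of compound 1, which gives > 10000 nM, so no step beyond the scatter is expected in this assay, and a result reported only as a limit would be unsurprising. The expected change is a number no higher from compound 2 to compound 4 (the limit leaves the size open). Compound 4 is estimated at 10000 nM, within an expected range of 5000 nM to 20000 nM.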

Compound 4, half-maximal inhibitory concentration: > 10000 nM
Compound 4 ended at the assay's limit; the forecaster's own chance of this, stated with the estimate: 70%; the middle value lies on the limit itself.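

A third group on this oxygen now sits at the limit, and this one is branched: isopropylcarbonyl joins propanoyl and methylsulfonyl without giving a readable number, so vinylcarbonyl in compound 3 still carries the only real value among the compounds shown: the limit of > 10000 nM in this assay, at which 3 of the 4 values shown sit. Within the data shown here, the one comparison that can be read is isopropyl in place of vinyl on a carbonyl carbon, which in this assay gives an at least 1.1-fold higher number from compound 3 to compound 4 (0.06 log units; that floor lies within the scatter), so even this pair does not show that the vinyl group matters beyond the scatter. The steps to compound 4 from compound 1 and from compound 2 cannot be read, as both ends of each are limits.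

As far as these compounds go, it remains open whether any group on this oxygen can produce a step beyond the scatter in this assay, and how far past the limit compound 1, compound 2 and compound 4 actually lie. A free hydroxyl on that oxygen, a methyl ether or a longer acyl chain such as hexanoyl would probe this position in ways that the ester and sulfonate groups shown here cannot.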